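From Thiophen-3-yl to Ethynyl: One Swap, One Open Question

The source may hold more compounds than are shown below. What is called first, only, known or untested is meant among the compounds shown, and "the series" means these compounds.

Of the compounds shown here, two with a shared core have numbers so far. In an ADME assay on BJ cells (Homo sapiens), read by MTT assay, with a stated time of 72 h (on this read-out higher numbers stand for weaker inhibition and lower numbers for stronger inhibition), compound 1 (`C#Cc1cn([C@@H]2O[C@H](CO)[C@@H](O)[C@H]2O)c2ncnc(SC)c12`) gives 68600 nM and compound 2 (`Cc1ncnc2c1c(-c1ccsc1)cn2[C@@H]1O[C@H](CO)[C@@H](O)[C@H]1O`) gives 96900 nM as its result. Compound 2 therefore stands within the usual scatter of compound 1, so repeated measurements could not separate the two. They also differ in two places, which means this pair does not isolate the effect of any single group.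

Compound 3 (`C#Cc1cn([C@@H]2O[C@H](CO)[C@@H](O)[C@H]2O)c2ncnc(C)c12`) has not yet been measured. It matches compound 2 except at one place, an aromatic carbon of a five-membered aromatic ring with 1 nitrogen. The change (ethynyl in place of thiophen-3-yl on an aromatic carbon) puts ethynyl in place of thiophen-3-yl there. A large step is not expected in this assay because the ethynyl-bearing compound 1 gives 68600 nM on this read-out. The expected step (a 1.5-fold lower number from compound 2 to compound 3 (0.17 log units; within the scatter)) is therefore small, although a single comparison offers thin support. For compound 3 the estimate is 65000 nM with an expected range from 22000 nM to 150000 nM in this test.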

Compound 3, half-maximal inhibitory concentration: 50 nM
The estimate for compound 3 lay 1300-fold (3.11 log units) above the measured number, outside the stated range (below it).
By their numbers in this assay, from the lowest: compound 3; then compounds 1 and 2 (each within the scatter of the next).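

In this assay, ethynyl in place of thiophen-3-yl on the aromatic carbon of the five-membered ring gives a 1900-fold lower number from compound 2 to compound 3 (3.29 log units; beyond the scatter), so the group at this position can matter greatly, which the earlier pair could not reveal. With ethynyl held in place, methyl in place of methylsulfanyl on an aromatic carbon gives a 1400-fold lower number from compound 1 to compound 3 (3.14 log units; beyond the scatter), so the second place matters just as much. Compound 1 carries ethynyl without methyl, compound 2 carries methyl without ethynyl, and both have high numbers, while compound 3 carries both groups and has a far lower number, so the size of each swap here depends on the group at the other place.

No supporting measurement bears on why these two steps are so large, so the data show their size but not their cause. Still open, going by these compounds, is how narrow this requirement is: whether a nitrile or a longer chain with a triple bond could stand in for ethynyl, and whether an amine or an ethyl group could stand in for methyl, while keeping the low number.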